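The source may hold more compounds than are shown below. What is called first, only, known or untested is meant among the compounds shown, and "the series" means these compounds.

Going by the values given here, in a functional assay on MCF7 cells (Homo sapiens) for antiproliferative activity, read by MTT assay, with a stated time of 72 h (on this read-out higher numbers stand for weaker inhibition and lower numbers for stronger inhibition), compound 2 `COc1ncc(-c2ccc3nc(NC4CC4)sc3c2)cc1NS(=O)(=O)c1ccc(F)cc1` gives 450 nM, the only number returned by the three measured compounds. Compound 1 `CCCNc1nc2ccc(-c3cnc(Cl)c(NS(=O)(=O)c4ccc(F)cc4)c3)cc2s1` is reported as "not determined" (no result reported) in this assay, and compound 3 `O=S(=O)(Nc1cc(-c2ccc3nc(NC4CC4)sc3c2)cnc1Cl)c1ccc(F)cc1` is likewise reported as "not determined" (no result reported), so compound 3 stands without a single number, one further entry sharing that position. Compound 4 `CCN(CC)CCNC(=O)Nc1nc2ccc(-c3cnc(Cl)c(NS(=O)(=O)c4ccc(F)cc4)c3)cc2s1` differs from compound 3 by (2-(diethylamino)ethyl)carbamoyl in place of cyclopropyl on a nitrogen on an aromatic ring. Among the compounds with values here, no measured pair isolates this change, so the size and direction of the step in this assay cannot be read from the data; the expectation is that any shift stays close to the scatter, with neither direction favoured. Within the data shown here, the only anchor is compound 2 at 450 nM. Compound 4 is therefore estimated at 350 nM, within a range from 70 nM to 1800 nM.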

Compound 4, half-maximal inhibitory concentration: 710 nM
Estimate against measurement, compound 4: 2.0-fold (0.31 log units) below; low and high end bracket the measured number.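

Going by these compounds alone, compound 4 adds no new step, as compound 3 has no single number to set against it in this assay. The compounds shown leave open what replacing cyclopropyl with (2-(diethylamino)ethyl)carbamoyl does on its own in this assay. No evidence bears on this result.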